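Methoxy in place of methyl: what to expect for compound 4

The source may hold more compounds than are shown below. What is called first, only, known or untested is meant among the compounds shown, and "the series" means these compounds.

Compound 3 `Cc1ccccc1NC(=S)N1CCc2c(sc(NC(=O)c3ccccc3Cl)c2C(N)=O)C1` shows the lowest number of the three compounds measured in a functional assay on MKN-74 cells (Homo sapiens) for antiproliferative activity, with a stated time of 24 h (a lower number here means a stronger inhibitor, a higher number a weaker inhibitor), at 11700 nM. Compound 1 `NC(=O)c1c(NC(=O)c2ccccc2Cl)sc2c1CCNC2` gives 28700 nM and compound 2 `NC(=O)c1c(NC(=O)c2ccccc2Cl)sc2c1CCN(Cc1ccc(Cl)cc1)C2` gives 18700 nM. The measured steps are a 2.5-fold lower number from compound 1 to compound 3 (0.39 log units; beyond the scatter), which lies beyond the scatter, and a 1.5-fold lower number from compound 1 to compound 2 (0.19 log units; within the scatter) and a 1.6-fold lower number from compound 2 to compound 3 (0.20 log units; within the scatter), both within it; each of them changes only the group on an amine nitrogen in a ring of the shared core. Compound 4 `COc1ccccc1NC(=S)N1CCc2c(sc(NC(=O)c3ccccc3Cl)c2C(N)=O)C1` differs from compound 3 by methoxy in place of methyl on an aromatic carbon, placed on an aromatic carbon of a six-membered aromatic ring of carbon only, ortho to a large group. Within the data shown here, no measured step touches that ring, so nothing here points to a move beyond the scatter. In this assay compound 4 is therefore expected to give about 11000 nM, with a range from 4500 nM to 28000 nM. The expected step is a 1.1-fold lower number from compound 3 to compound 4 (0.03 log units; within the scatter).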

Compound 4, half-maximal inhibitory concentration: 35200 nM
Compound 4: the middle estimate sits 3.2-fold (0.51 log units) below what was measured; the whole stated range lies below it.
By their numbers in this assay, from the lowest: compounds 3, 2, 1 and 4 (each within the scatter of the next, the first and the last beyond it).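

In this assay, among these compounds, this position on the aromatic ring, which no earlier step touched, matters: methoxy in place of methyl gives a 3.0-fold higher number from compound 3 to compound 4 (0.48 log units; beyond the scatter) as the measured step. The advantage of compound 3 over the unsubstituted amine does not survive this change, with a 1.2-fold higher number from compound 1 to compound 4 (0.09 log units; within the scatter) and a 1.9-fold higher number from compound 2 to compound 4 (0.27 log units; within the scatter) as the remaining steps. Nothing available here explains this result.

On these data alone, whether a hydroxyl, a fluorine or an ethyl at this position would behave more like methyl or like methoxy stays open. So does the effect of methoxy elsewhere on that ring.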